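The source may report more compounds than this note shows. Statements on the series, on what has been measured and on what is new or still open speak of the compounds shown alone.

Compound 1 `CC(C)(C)C[C@H](N)C(=O)Nc1cc2cc[nH]c(=O)c2cc1Cl` — in a functional assay (aorta) with Rattus norvegicus as the target; on this read-out higher numbers stand for an effect only at larger amounts of compound and lower numbers for an effect already at smaller amounts: "not determined" (no result reported)
Compound 2 `CC(C)[C@@H](N)C(=O)Nc1cc2cc[nH]c(=O)c2cc1Cl` — in this assay: "not determined" (no result reported)
Compound 3 `CN1CCC(C(=O)Nc2cc3cc[nH]c(=O)c3cc2Cl)CC1` — in this assay: 250 nM

Compound 1 stands without a number here: in this assay compound 1 has no reported result, and compound 2 likewise has none. The only figure in the set belongs to compound 3, which in this assay gives 250 nM. Within the data shown here, no step between two measured compounds can therefore be given.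

Compound 4 `N[C@H]1CC[C@@H](C(=O)Nc2cc3cc[nH]c(=O)c3cc2Cl)CC1` differs from compound 1 in one place: 4-aminocyclohexyl in place of 1-amino-3,3-dimethylbutyl on a carbonyl carbon. With compound 1 unmeasured, no direction or size of step from compound 1 to compound 4 in this assay can be stated from the data; the expectation for compound 4 rests on compound 3 alone, which also carries a six-membered ring bearing a nitrogen on the carbonyl carbon and gives 250 nM. On that basis compound 4 is expected to land in this assay at about 300 nM, with a plausible range from 60 nM to 1500 nM.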

Compound 4, half-maximal effective concentration: 180 nM
Compound 4: the middle estimate sits 1.7-fold (0.22 log units) above what was measured, and the stated range covers the measured number.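

In this assay, placing 4-aminocyclohexyl instead of 1-methylpiperidin-4-yl on a carbonyl carbon gives a 1.4-fold lower number from compound 3 to compound 4 (0.14 log units; within the scatter) and so does not separate the two groups on this read-out. Among these compounds, this is the first step that can be read at this position, and it shows that a value of this size also occurs when the nitrogen sits on a six-membered ring of carbon only rather than within the ring. Steps involving compound 1 and compound 2 cannot be read, and no supporting data explain the result.

The compounds shown leave open how an open-chain group such as 1-amino-3,3-dimethylbutyl compares with these ring groups. They also leave open whether a carboxylic acid or a phenyl ring on the same carbonyl carbon would fit this picture.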